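Benzimidazolylmethyl sulfanyl variant: cytotoxicity outlook

A few compounds are considered here, and "the series" means these few. Any claim that something is new, unique, unknown or untested is made for them only; others in the source may bear on it.

The series shares one core, varied only at the group on the saturated chain carbon bound to the sulfur. Compound 1 `Cc1cc(N2CC[C@@H](C)[C@@H](N(C)c3ncnc4[nH]ccc34)C2)n2nc(SCC3CCCCC3)nc2n1` carries cyclohexyl there, and in a toxicity assay on GES1 cells (Homo sapiens) for inhibition, read by MTT assay, with a stated time of 72 h (on this read-out lower numbers stand for stronger inhibition and higher numbers for weaker inhibition), compound 1 gives 98200 nM. Compound 2 `Cc1cc(N2CC[C@@H](C)[C@@H](N(C)c3ncnc4[nH]ccc34)C2)n2nc(SCc3ccc(C(F)(F)F)cc3)nc2n1` carries 4-(trifluoromethyl)phenyl, and in this assay compound 2 gives 17300 nM. Compound 3 `Cc1cc(N2CC[C@@H](C)[C@@H](N(C)c3ncnc4[nH]ccc34)C2)n2nc(SCc3ccc(Cl)cc3)nc2n1` carries 4-chlorophenyl. In this assay compound 3 gives only a limit, > 100000 nM (the limit of > 100000 nM in this assay, at which 1 of the 3 values shown sits). Among the measured compounds shown here, the steps leading to compound 3 read an at least 1.0-fold higher number from compound 1 to compound 3 (0.00 log units; that floor lies within the scatter) and an at least 5.7-fold higher number from compound 2 to compound 3 (0.76 log units; beyond the scatter), while the step of a 5.7-fold lower number from compound 1 to compound 2 (0.75 log units; beyond the scatter) is the only one with a number at both ends.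

Compound 4 `Cc1cc(N2CC[C@@H](C)[C@@H](N(C)c3ncnc4[nH]ccc34)C2)n2nc(SCc3nc4ccccc4[nH]3)nc2n1` differs from compound 3 by 1H-benzimidazol-2-yl in place of 4-chlorophenyl on a saturated chain carbon bound to a sulfur. For the measured compounds named here, no measured step exchanges an aromatic group for a benzimidazolyl, so none bears directly on this change; the three measured values together occupy a narrow band of weak inhibition, and even the lowest number, that of compound 2, lies far from strong inhibition. The step of an at least 1.1-fold lower number from compound 3 to compound 4 (0.04 log units; that floor lies within the scatter) in this assay is therefore expected to be none beyond the scatter, in either direction. For compound 4 the estimated value in this assay is 90000 nM, with a range from 25000 nM to 300000 nM.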

Compound 4, half-maximal inhibitory concentration: 40200 nM
Estimate against measurement, compound 4: 2.2-fold (0.35 log units) above; low and high end bracket the measured number.
By their numbers in this assay, from the lowest: compound 2; then compound 4; then compound 1. At a limit, above all of these: compound 3.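

In this assay, compound 3 stands at a limit and not at a number: the limit of > 100000 nM in this assay, at which 1 of the 4 values shown sits. With that reservation, 1H-benzimidazol-2-yl on a saturated chain carbon bound to a sulfur gives an at least 2.4-fold lower number from compound 3 to compound 4 (0.39 log units; beyond the scatter) and a 2.4-fold lower number from compound 1 to compound 4 (0.39 log units; beyond the scatter), so this position also accepts a group with a five-membered aromatic ring holding 2 hetero atoms, and with a hydrogen-bond donor and acceptor, while the reading remains in weak inhibition. The exchange against 4-(trifluoromethyl)phenyl gives a 2.3-fold higher number from compound 2 to compound 4 (0.37 log units; beyond the scatter), so compound 2 keeps the lowest number and the position now shows three separate levels where the earlier measured numbers showed two.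

The compounds shown do not separate the hydrogen-bond donor of 1H-benzimidazol-2-yl from its added ring, and a pyridinyl, an amine or a carboxylic acid on the same chain carbon would be needed to pull those features apart. Also open, as far as these compounds go, is how much of the weak inhibition belongs to the shared core, which is the same in all four compounds, and whether the order of compound 2, compound 4 and compound 1 holds for other aromatic groups at this position.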